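This account rests on a few compounds, and the source may have more. Where it says the series, first, only, none or still open, it means among the compounds named here.

Values in a physicochemical assay for solubility; on this read-out higher numbers stand for higher solubility and lower numbers for lower solubility:
- Compound 1 `COc1ccc(C(=O)Nc2ccc([N+](=O)[O-])cc2Cl)c(O)c1`: < 1 ug/mL (a limit)
- Compound 2 `O=C(Nc1ccccc1Cl)c1cc(Cl)ccc1O`: 5 ug/mL
- Compound 3 `O=C(Nc1ccccc1C(F)(F)F)c1cc(Cl)ccc1O`: > 47 ug/mL (a limit)

Within the data shown here, compound 2, at 5 ug/mL, holds the only true number in this small set. Compound 1 reads < 1 ug/mL, which is a limit of the assay and not a number. Compound 3 reads > 47 ug/mL, which is also a limit.

The next compound to be tested is compound 4 `O=C(Nc1ccc(Cl)cc1Cl)c1cc(Cl)ccc1O`. It differs from compound 2 by chloro in place of hydrogen on an aromatic carbon.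

Among the measured compounds shown here, only one measured step offers a guide, and it is a different change: an at least 9.4-fold higher number from compound 2 to compound 3 (0.97 log units; beyond the scatter), with trifluoromethyl in place of chloro on an aromatic carbon. That step shows that one small swap can move the read-out in this assay well beyond the scatter, but it does not carry over directly to a new chloro group. Compound 1, at its limit of < 1 ug/mL, shows how low this set can fall. A modest fall is therefore expected, though one that may barely clear the scatter, estimated as a 2.5-fold lower number from compound 2 to compound 4 (0.40 log units; beyond the scatter). For compound 4 the expected value is 2 ug/mL, with an estimated range of 0.7 ug/mL to 6 ug/mL.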

Compound 4, solubility: < 1 ug/mL
Compound 4 gave a limit, no number (the forecaster's own chance of this, stated with the estimate: 30%); middle value at least 2.0-fold (0.30 log units) away from the limit.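

In this assay, chloro in place of hydrogen on an aromatic carbon, meta to a chloro group and para to a large group, gives an at least 5.0-fold lower number from compound 2 to compound 4 (0.69 log units; beyond the scatter). Among these compounds, this is the first measured step at this position and the first downward step in the set: the earlier step exchanged one group for another elsewhere, whereas here a single added chlorine atom replaces only a hydrogen and still moves the read-out beyond the scatter. Compound 4 stands at a limit and not at a number, so the step gives only the smallest possible size of the fall: the limit of < 1 ug/mL in this assay, at which 2 of the 4 values shown sit.

Among the compounds shown here, the true size of the fall remains unknown, and with only one group tested at this position, the result cannot separate an effect specific to chloro from one shared by other groups placed there. An amine or a carboxylic acid on the same aromatic carbon would show whether the read-out falls with other groups at this position or moves the other way.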